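This account rests on a few compounds, and the source may have more. Where it says the series, first, only, none or still open, it means among the compounds named here.

Of the compounds shown here, three from one series have been measured in a functional assay, read by spectrophotometry, with a stated time of 3 min; a lower number here means a stronger inhibitor, a higher number a weaker inhibitor. Compound 1 `Cc1ccc2[nH]c(=O)c(/C=N/c3ccccc3O)cc2c1` gives 8240 nM. Compound 2 `NS(=O)(=O)CC(=O)N/N=C/c1cc2ccccc2[nH]c1=O` gives 8910 nM in this assay, a number that sits within the scatter of the number for compound 1, so the two cannot be told apart. Compound 3 `Cc1ccc2[nH]c(=O)c(/C=N/c3ccc(C(=O)O)cc3)cc2c1`, by contrast, gives 222000 nM, the highest number of the three and clearly beyond the scatter from compound 2; it is the weakest inhibitor shown. Compound 2 thus stands among the stronger pair of the set, and it is the starting point for the next compound.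

Compound 4 `O=c1[nH]c2ccccc2cc1/C=N/Nc1ccccc1` has not yet been measured in this assay. It differs from compound 2 in one place: phenyl in place of (sulfamoylmethyl)carbonyl on an amine nitrogen. Among the compounds with values here, no measured pair shows a change of this kind, so the size and direction of the effect can only be guessed. The expectation is a modest step from compound 2 to compound 4 of a 1.7-fold higher number from compound 2 to compound 4 (0.23 log units; within the scatter), towards a somewhat weaker inhibitor. Compound 4 is therefore expected to give about 15000 nM in this assay, most likely within 3000 nM to 60000 nM.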

Compound 4, half-maximal inhibitory concentration: 11800 nM
For compound 4 the middle estimate is 1.3-fold (0.10 log units) above the measured one; measured number inside the range.
By their numbers in this assay, from the lowest: compounds 1, 2 and 4 (each within the scatter of the next); then compound 3.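

In this assay, phenyl in place of (sulfamoylmethyl)carbonyl on an amine nitrogen gives a 1.3-fold higher number from compound 2 to compound 4 (0.12 log units; within the scatter) and so separates the two compounds by no more than repeat measurements would. This first measured pair differing in one place shows that a group with no ring, holding a hydrogen-bond donor and acceptors, and an aromatic ring of carbon only, holding neither, cannot be told apart at this position. No measurement at hand bears on why the two groups give such similar numbers.

One pair cannot show whether other groups on this nitrogen, such as acetyl, benzyl or a longer chain, would also stay within the scatter. It also leaves open whether a fluorine or an amine on the phenyl would shift the number.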